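Branching the Ester Alkyl of an Adenine Hydroxypropanoate Series

A few compounds are considered here, and "the series" means these few. Any claim that something is new, unique, unknown or untested is made for them only; others in the source may bear on it.

The measured compounds:
compound 1, `COCCOC(=O)C(O)Cn1cnc2c(N)ncnc21`, > 400 ug/mL
compound 2, `CCCCOC(=O)C(O)Cn1cnc2c(N)ncnc21`, 200 ug/mL
compound 3, `CCOC(=O)C(O)Cn1cnc2c(N)ncnc21`, > 400 ug/mL

In a functional assay on Vero cells (Chlorocebus sabaeus) for cytotoxicity (on this read-out higher numbers stand for lower toxicity in this test and lower numbers for higher toxicity in this test), compound 3 gives > 400 ug/mL, which is a limit of this assay and not a number. Compound 1 likewise gives > 400 ug/mL, again a limit. Among the compounds with values here, compound 2 gives 200 ug/mL, the one true number among the three. Within the data shown here, the step of an at least 2.0-fold higher number from compound 2 to compound 3 (0.30 log units; that floor lies within the scatter) is therefore the one readable change, while a step that the two limits leave unreadable from compound 1 to compound 3 cannot be sized. Both limits sit at the limit of > 400 ug/mL in this assay, at which 2 of the 3 values shown sit.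

Compound 4, `CCC(C)OC(=O)C(O)Cn1cnc2c(N)ncnc21`, has yet to be measured. It differs from compound 3 by ethyl in place of hydrogen on a saturated chain carbon bound to an oxygen next to a carbonyl group and a saturated chain carbon. The step that bears on this change is an at least 2.0-fold higher number from compound 2 to compound 3 (0.30 log units; that floor lies within the scatter), since it too concerns an alkyl group on the ester side and runs in the opposite direction; read backwards, it suggests that a larger alkyl on that side lowers the number. The change here places the ethyl on the carbon bound to the ester oxygen rather than further out, so the size is uncertain. Compound 4 is estimated at 250 ug/mL, with a range from 100 ug/mL to 500 ug/mL. The step of an at least 1.6-fold lower number from compound 3 to compound 4 (0.20 log units; that floor lies within the scatter) is the expected downward move, with a fair chance that only a limit is reported.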

Compound 4, minimum cytotoxic concentration: > 400 ug/mL
Compound 4: no number, only a limit; the forecaster's own chance of this, stated with the estimate: 35%; middle value at least 1.6-fold (0.20 log units) away from the limit.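

Compound 4 gives only a limit in this assay, and it is the limit that now holds most of the series: the limit of > 400 ug/mL in this assay, at which 3 of the 4 values shown sit. Within the data shown here, the one step that can be read is an at least 2.0-fold higher number from compound 2 to compound 4 (0.30 log units; that floor lies within the scatter), with sec-butyl in place of butyl on an oxygen next to a carbonyl group, and that floor alone does not separate the two esters beyond the usual scatter. The steps to compound 4 from compound 1 and from compound 3 cannot be read, so ethyl in place of hydrogen at this position gives no sized change, yet the sec-butyl ester shows that a larger alkyl on the ester oxygen does not always bring a true number, with compound 2 still the only ester that has one.

As far as these compounds go, how the compounds at the limit truly rank, and whether butyl and sec-butyl really differ, stays open. Also open, from the compounds shown here alone, is whether a longer chain on the ester oxygen, such as octyl, or a free carboxylic acid in place of the ester would give a true number in this assay.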